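This account rests on a few compounds, and the source may have more. Where it says the series, first, only, none or still open, it means among the compounds named here.

Working notes on the series. Compound 1 `CCOc1ccccc1-c1ccc(-c2nc3cnccc3c(NC(C)C(=O)O)c2C#N)cc1` is the reference; in a physicochemical assay for lipophilicity, read by HPLC, at pH 7.5 (on this read-out higher numbers stand for higher lipophilicity and lower numbers for lower lipophilicity), compound 1 gives 2.1, the lowest of the three numbers recorded. Compound 2 `CC[C@@H](Nc1c(C#N)c(-c2ccc(-c3ccc(OC)cc3)cc2)nc2cnccc12)C(N)=O` gives 2.7 and compound 3 `CC[C@@H](Nc1c(C#N)c(-c2ccc(-c3ccc(Cl)cc3)cc2)nc2cnccc12)C(N)=O` gives 3.1; both sit above compound 1 by more than the scatter. Among the compounds with values here, the one measured step, a number 0.40 log units higher from compound 2 to compound 3 (beyond the scatter), changes a substituent on the distal aromatic ring and leaves the group on the amine untouched, so it does not bear directly on the change considered here. Compound 4 `CCOc1ccccc1-c1ccc(-c2nc3cnccc3c(N[C@H](CC(C)C)C(N)=O)c2C#N)cc1` differs from compound 1 in one place: 1-carbamoyl-3-methylbutyl in place of 1-carboxyethyl on a nitrogen on an aromatic ring. Within the data shown here, no measured pair shows this exchange, so the expectation rests on the values of compound 2 and compound 3, which both carry a carbamoyl group on that nitrogen and both sit well above compound 1; the entering group is also larger than the ethyl-bearing side chains of those two. Compound 4 is therefore expected to rise, a number 1.40 log units higher from compound 1 to compound 4 (beyond the scatter), to an estimated 3.5 with a range of 2.9 to 4.1.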

Compound 4, distribution coefficient: 3.4
For compound 4 the middle estimate is 0.10 log units above the measured one; measured number inside the range.
By their numbers in this assay, from the lowest: compound 1; then compound 2; then compounds 3 and 4 (each within the scatter of the next).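

In this assay, the group on this nitrogen now has a direct reading, with the rest of compound 1 unchanged: 1-carbamoyl-3-methylbutyl in place of 1-carboxyethyl gives a number 1.30 log units higher from compound 1 to compound 4 (beyond the scatter). This single exchange at the nitrogen produces a large step, whereas the change on the distal aromatic ring gives only a modest one (a number 0.40 log units higher from compound 2 to compound 3 (beyond the scatter)). The exchange alters the carboxylic acid and the side chain together, and no measurement on hand accounts for the size of the step.

The compounds shown do not separate these two parts of the exchange, which a 1-carbamoylethyl or a 1-carboxy-3-methylbutyl group on the same nitrogen would do. On these data alone, how a basic amine or a longer chain at this position would read also remains open.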